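Removing One Methoxy Group: A Step Expected to Stay Small

The compounds below may be only part of what the source reports. "The series", "measured", "known", "first", "only" and "open" are said of these compounds alone.

Compound 1, `COc1cccc(Oc2ccc3cc(NC(=O)c4ccc(OC(C)=O)c(CC=C(C)C)c4)c(=O)oc3c2C)c1`: 13700 nM
Compound 2, `COCOc1ccc(Cc2ccc3cc(NC(=O)c4ccc(OC(C)=O)c(CC=C(C)C)c4)c(=O)oc3c2C)cc1OC`: 14200 nM

Both compounds were tested in a functional assay on SK-BR-3 cells (Homo sapiens) for antiproliferative activity; a higher number here means a weaker inhibitor, a lower number a stronger inhibitor. Compound 2 and compound 1 give numbers that lie within the usual scatter of each other, so neither stands apart. Compound 3, `COCOc1ccc(Cc2ccc3cc(NC(=O)c4ccc(OC(C)=O)c(CC=C(C)C)c4)c(=O)oc3c2C)cc1`, differs from compound 2 in one place: hydrogen in place of methoxy on an aromatic carbon. Among the measured compounds shown here, no pair of measured compounds shows what such a removal does here, so the step is expected to be none beyond the scatter, as a 1.0-fold lower number from compound 2 to compound 3 (0.01 log units; within the scatter). Compound 3 is therefore estimated to give 14000 nM in this assay, with a range from 5000 nM to 40000 nM.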

Compound 3, half-maximal inhibitory concentration: 13500 nM
Compound 3: middle estimate off by 1.0-fold (0.02 log units), on the high side; measured number inside the range.
By their numbers in this assay, from the lowest: compounds 3, 1 and 2 (each within the scatter of the next).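

In this assay, hydrogen in place of methoxy on this aromatic carbon, ortho to a methoxymethoxy group, leaves the number level (a 1.1-fold lower number from compound 2 to compound 3 (0.02 log units; within the scatter)), so the two cannot be told apart here. A larger change, 4-(methoxymethoxy)benzyl in place of 3-methoxyphenoxy, also stays within the scatter (a 1.0-fold lower number from compound 1 to compound 3 (0.01 log units; within the scatter)). No measurement is available that bears on why these numbers stay level. On these data alone, whether an amine or a carboxylic acid on this carbon would shift the number remains open. So does the effect of replacing the methoxymethoxy group itself.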